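The compounds below may be only part of what the source reports. "The series", "measured", "known", "first", "only" and "open" are said of these compounds alone.

Measured in an ADME assay on HCT-116 cells (Homo sapiens) for cytotoxicity, read by CellTiter-Glo, with a stated time of 72 h (on this read-out lower numbers stand for stronger inhibition and higher numbers for weaker inhibition), each entry being a limit and not a number:

Compound 1 `CC1CCN(C2CCN(S(=O)(=O)c3ccc(C#N)cc3)CC2)CC1`: > 5000 nM
Compound 2 `CC1CCN(C2CCN(S(=O)(=O)c3cccnc3F)CC2)CC1`: > 10000 nM
Compound 3 `CC1CCN(C2CCN(S(=O)(=O)c3ccc(Br)c(Cl)c3)CC2)CC1`: > 5000 nM

Compound 3 gives > 5000 nM, which is a limit of the assay. It stands at the limit of > 5000 nM in this assay, at which 2 of the 3 values shown sit. No number is therefore known for compound 3, only a limit.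

The next compound, compound 4 `CC1CCN(C2CCN(S(=O)(=O)c3ccc(Cl)c(Cl)c3)CC2)CC1`, carries one change: chloro in place of bromo on an aromatic carbon. This is chloro in place of bromo on an aromatic carbon, para to a large group, so that 4-bromo-3-chlorophenyl becomes 3,4-dichlorophenyl.

The measured steps that bear on this are a step that the two limits leave unreadable from compound 1 to compound 3 and a step that the two limits leave unreadable from compound 2 to compound 3. Each exchanges the whole group on the sulfonyl sulfur, and neither gives a size that can be carried over. Among the compounds with values here, no measured step exchanges bromo for chloro alone. In this assay, no step beyond the scatter is therefore expected, and compound 4 is expected to reach a limit as well. The estimate means a step that the limit leaves unreadable from compound 3 to compound 4. Compound 4 is estimated at 7000 nM, with an expected range from 3000 nM to 20000 nM.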

Compound 4, half-maximal inhibitory concentration: > 5000 nM
Compound 4: no number, only a limit (the forecaster's own chance of this, stated with the estimate: 85%); the middle value is on the limit's open side.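

Compound 4, like compound 1, compound 2 and compound 3, has only a limit in this assay, so no step among these compounds can be read. As far as these compounds go, what number any of them would give, and whether the group on the sulfonyl sulfur matters, stays open.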